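Series notes: chloro step from compound 3 to compound 4

The source may hold more compounds than are shown below. What is called first, only, known or untested is meant among the compounds shown, and "the series" means these compounds.

Within the data shown here, compound 1 `O=C(O)CCCCC(CCSC(=O)c1ccccc1)SC(=O)c1ccccc1` is the only member of this set with a number: in a functional assay on PC-3 cells (Homo sapiens) for inhibition, read by MTT assay, with a stated time of 24 h, tested at 1 ug/mL (on this read-out higher numbers stand for more inhibition of growth at the one concentration tested and lower numbers for less inhibition of growth), compound 1 gives 9.86%, a weak effect at the single concentration. Compound 2 `O=C(CCCCC1CCSS1)NO` and compound 3 `O=C(CCCCC1CCSS1)Nc1ccccn1` carry an amide in place of the acid of compound 1, with the shared core cyclised; in this assay compound 2 gives "not determined" (no result reported), and compound 3 gives "not determined" (no result reported). Compound 3 therefore stands without a number of its own, alongside one further compound that also has none, so its position relative to compound 1 cannot be read.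

Compound 4 `O=C(CCCCC1CCSS1)Nc1ccc(Cl)cn1` differs from compound 3 by chloro in place of hydrogen on an aromatic carbon. Among the measured compounds shown here, no pair of measured compounds differing in one place exists, so the size of this step has no anchor. Given only the weak effect of compound 1 at 9.86% as a reference, the expectation is a small step, none beyond the scatter, in either direction. Compound 4 is expected to give 12%, within a range of 0% to 35%.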

Compound 4, percent growth inhibition at one concentration: 2%
The estimate for compound 4 lay 10 percentage points above the measured number; the range from low to high includes it.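

The chloro step between compound 3 and compound 4 cannot be read: compound 3 has no single number to set against compound 4. The compounds shown leave open whether chloro in place of hydrogen on this aromatic carbon changes growth inhibition at all in this assay. Nothing available bears on a cause for the result of compound 4.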